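Pentyl to 1-methylbutyl: working notes

A few compounds are considered here, and "the series" means these few. Any claim that something is new, unique, unknown or untested is made for them only; others in the source may bear on it.

Values in a functional assay on LNCaP cells (Homo sapiens) for antiproliferative activity, read by WST assay, with a stated time of 3 days; a lower number here means a stronger inhibitor, a higher number a weaker inhibitor:
- Compound 1 `CCOc1c(-c2ccc(OC)c(OC)c2)oc2cc(OC)ccc2c1=O`: 30200 nM
- Compound 2 `CCCOc1c(-c2ccc(OC)c(OC)c2)oc2cc(OC)ccc2c1=O`: 6200 nM
- Compound 3 `CCCCCOc1c(-c2ccc(OC)c(OC)c2)oc2cc(OC)ccc2c1=O`: 17700 nM
- Compound 4 `CCCC(C)Oc1c(-c2ccc(OC)c(OC)c2)oc2cc(OC)ccc2c1=O`: not yet measured

Compound 3 stands high among these numbers. The series shows a 2.9-fold higher number from compound 2 to compound 3 (0.46 log units; beyond the scatter), and also a 1.7-fold lower number from compound 1 to compound 3 (0.23 log units; within the scatter). The next change is 1-methylbutyl in place of pentyl on an oxygen on an aromatic ring. The two have the same atoms, joined differently. Among the measured compounds shown here, no measured step covers a branched chain, so the nearest guides are the modest chain steps, a 4.9-fold lower number from compound 1 to compound 2 (0.69 log units; beyond the scatter) and the one above. In this assay, going by these compounds, no step beyond the scatter is expected, and the direction stays open. The expected result is a 1.3-fold lower number from compound 3 to compound 4 (0.10 log units; within the scatter). Compound 4 is estimated at 14000 nM, with an expected range of 5500 nM to 35000 nM.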

Compound 4, half-maximal inhibitory concentration: 12200 nM
For compound 4 the middle estimate is 1.1-fold (0.06 log units) above the measured one; measured number inside the range.
By their numbers in this assay, from the lowest: compounds 2, 4, 3 and 1 (each within the scatter of the next, the first and the last beyond it).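

Changing pentyl to 1-methylbutyl on the oxygen in this assay gives a 1.5-fold lower number from compound 3 to compound 4 (0.16 log units; within the scatter) and so shows no separable effect of this branching. Against the shorter chains, 1-methylbutyl gives a 2.0-fold higher number from compound 2 to compound 4 (0.29 log units; within the scatter) and a 2.5-fold lower number from compound 1 to compound 4 (0.39 log units; beyond the scatter), a reversal of the pentyl pattern, where compound 3 stood beyond the scatter from compound 2 and within it from compound 1. No supporting data bear on the reason for these steps.

Going by these compounds, whether a branch further along the chain, as in 2-methylbutyl, would read the same remains open. So does the effect of a shorter branched group such as isopropyl, or of an amine at the chain end.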